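Ester to Thioamide on a Shared Aminothiophene Core

This account rests on a few compounds, and the source may have more. Where it says the series, first, only, none or still open, it means among the compounds named here.

Compound 1 `Nc1sc(-c2ccccc2)c(-c2ccc(Cl)cc2)c1C(=O)NCc1ccccc1` gives 22800 nM in a functional assay on PC-3 cells (Homo sapiens) for cytotoxicity, read by sulforhodamine B assay, with a stated time of 72 h; a higher number here means a weaker inhibitor, a lower number a stronger inhibitor. Compound 2 `COC(=O)c1c(N)sc(-c2ccc(Cl)cc2)c1-c1ccc(Cl)cc1` gives 2780 nM in this assay. Compound 3 `Nc1sc(-c2ccc(Br)cc2)c(-c2ccc(Cl)cc2)c1C(=O)NCc1ccccc1` reaches only a limit of this assay, > 50000 nM.

Among the two plain numbers, compound 2 stands lowest, with compound 1 giving the higher value. Going by the values given here, the one measured step that changes a single place, an at least 2.1-fold higher number from compound 1 to compound 3 (0.34 log units; beyond the scatter), concerns a halogen on an outer ring and ends at a limit; it is documented as the limit of > 50000 nM in this assay, at which 1 of the 3 values shown sits, for compound 3. It does not touch the position changed here.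

Compound 4 `CC(C)(C)NC(=S)c1c(N)sc(-c2ccc(Cl)cc2)c1-c1ccc(Cl)cc1` differs from compound 2 in the following way: a group of 7 heavy atoms (5 carbon, 1 nitrogen, 1 sulfur; no ring) in place of a group of 4 heavy atoms (2 carbon, 2 oxygen; no ring), on an aromatic carbon. Among the compounds with values here, no measured pair tests this exchange, so the expectation rests on weak ground. Since the amide-bearing compound 1 sits above the ester-bearing compound 2, a somewhat higher number is expected, with wide uncertainty, giving an estimated step of a 2.2-fold higher number from compound 2 to compound 4 (0.33 log units; beyond the scatter). Compound 4 is therefore estimated at 6000 nM, within a range from 1500 nM to 25000 nM.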

Compound 4, half-maximal inhibitory concentration: 34000 nM
The estimate for compound 4 lay 5.7-fold (0.75 log units) below the measured number; measured number outside the range, above it.
By their numbers in this assay, from the lowest: compound 2; then compounds 1 and 4 (each within the scatter of the next). At a limit, above all of these: compound 3.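

In this assay, going by these compounds alone, the exchange on this aromatic carbon gives a 12-fold higher number from compound 2 to compound 4 (1.09 log units; beyond the scatter) as a large step, the first measured change at this position. The amino group and both 4-chlorophenyl groups stay the same in this pair, so the position itself clearly matters to the read-out, something the earlier single-place step on an outer ring could not show. No measurement shown here explains the rise.

The exchange brings in sulfur, nitrogen and a larger carbon group all at once, and the compounds shown do not separate their contributions. Also open, going by these compounds, is how a tert-butyl amide, with oxygen in place of the sulfur, would compare, and how a carboxylic acid or a nitrile would fare at this position.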